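The compounds below may be only part of what the source reports. "The series", "measured", "known", "first", "only" and "open" are said of these compounds alone.

Compound 1 `C=C/C=C\[C@H](C)[C@H](OC(N)=O)[C@@H](C)[C@H](O)[C@@H](C)C/C(C)=C\[C@H](C)[C@@H](O)[C@@H](C)/C=C\CCc1cccc(O)c1C` gives 910 nM in a functional assay on A549 cells (Homo sapiens) for cytotoxicity (a higher number here means a weaker inhibitor, a lower number a stronger inhibitor), the second highest of the three numbers measured in this series; its nearest neighbour is compound 2 `C=C/C=C\[C@H](C)[C@H](OC(N)=O)[C@@H](C)[C@H](O)[C@@H](C)C/C(C)=C\[C@H](C)[C@@H](O)[C@@H](C)/C=C\CCc1cc(F)cc(F)c1`, which gives 1000 nM, and the furthest is compound 3 `C=C/C=C\[C@H](C)[C@H](OC(N)=O)[C@@H](C)[C@H](O)[C@@H](C)C/C(C)=C\[C@H](C)[C@@H](O)[C@@H](C)/C=C\CCc1ccccc1`, which gives 510 nM. The aryl swaps measured so far move the read-out little: a 1.1-fold higher number from compound 1 to compound 2 (0.04 log units; within the scatter), a 1.8-fold lower number from compound 1 to compound 3 (0.25 log units; within the scatter) and a 2.0-fold lower number from compound 2 to compound 3 (0.29 log units; within the scatter). Compound 4 `C=C/C=C\[C@H](C)[C@H](OC(N)=O)[C@@H](C)[C@H](O)[C@@H](C)C/C(C)=C\[C@H](C)[C@@H](O)[C@@H](C)/C=C\CCc1cccc(OC)c1` differs from compound 1 in the same region: 3-methoxyphenyl in place of 3-hydroxy-2-methylphenyl on a saturated chain carbon, two bonds along the chain from a double-bonded chain carbon. All three measured steps at this position stay within the scatter, so the step from compound 1 to compound 4 in this assay is expected to stay within it as well. The estimate for compound 4 is 700 nM, between 350 nM and 1400 nM. The expected step is a 1.3-fold lower number from compound 1 to compound 4 (0.11 log units; within the scatter).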

Compound 4, half-maximal inhibitory concentration: 600 nM
The estimate for compound 4 lay 1.2-fold (0.07 log units) above the measured number; low and high end bracket the measured number.
By their numbers in this assay, from the lowest: compounds 3, 4, 1 and 2 (each within the scatter of the next).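

In this assay, rearranging the same atoms from 3-hydroxy-2-methylphenyl to 3-methoxyphenyl takes the hydrogen-bond donors from 1 to 0 and gives a 1.5-fold lower number from compound 1 to compound 4 (0.18 log units; within the scatter), so losing the donor at this position produces no step beyond the scatter. Methoxy in place of hydrogen gives a 1.2-fold higher number from compound 3 to compound 4 (0.07 log units; within the scatter), and the change from 3,5-difluorophenyl gives a 1.7-fold lower number from compound 2 to compound 4 (0.22 log units; within the scatter), leaving all four aryl groups within the scatter of one another. Nothing available explains this flat read-out.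

Going by these compounds, whether an amine or a carboxylic acid on the phenyl, or a longer chain carrying it, would step beyond the scatter remains open.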